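The source may hold more compounds than are shown below. What is called first, only, known or untested is meant among the compounds shown, and "the series" means these compounds.

Measured in a functional assay on HepG2 cells (Homo sapiens) for antiproliferative activity, read by MTT assay, with a stated time of 24 h; a lower number here means a stronger inhibitor, a higher number a weaker inhibitor:
- compound 1 `COc1cccc(/C=C/C(=O)c2ccc(OC)c3c2OC(C)(C)C=C3)c1`: only a limit, > 10000 nM
- compound 2 `COc1ccc(C(=O)/C=C/c2ccc(O)cc2)c2c1C=CC(C)(C)O2`: only a limit, > 10000 nM

Compound 1 stands at the limit of this assay and gives no number there. Compound 2 also sits at that limit. Among the measured compounds shown here, the step that the two limits leave unreadable from compound 1 to compound 2 is therefore unreadable, since both ends are limits; it is the only measured step in the set, and it concerns the same position as the change to compound 3. What the data show is the limit of > 10000 nM in this assay, at which 2 of the 2 values shown sit, nothing more.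

Compound 3 `COc1ccc(C(=O)/C=C/c2cc(Cl)ccc2O)c2c1C=CC(C)(C)O2` carries the change (5-chloro-2-hydroxyphenyl in place of 3-methoxyphenyl on a double-bonded chain carbon bound to a double-bonded chain carbon). For the measured compounds named here, no measured step shows a readable direction for replacing the group at that position; the one step that touches it gives only two limits. The expected step that the limit leaves unreadable from compound 1 to compound 3 is thus none beyond the scatter, with a real chance that compound 3 also returns only a limit in this assay. For compound 3 the estimate in this assay is 15000 nM, within 3000 nM to 60000 nM.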

Compound 3, half-maximal inhibitory concentration: 6640 nM
Beside the measured number, compound 3's estimate is 2.3-fold (0.35 log units) above it; measured number inside the range.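

In this assay, among the compounds shown here, compound 3 is the first compound of the series to return a number rather than a limit, which gives this place on a double-bonded chain carbon bound to a double-bonded chain carbon its first readable end. On these data alone, the result reads as an at least 1.5-fold lower number from compound 1 to compound 3 (0.17 log units; that floor lies within the scatter) and as an at least 1.5-fold lower number from compound 2 to compound 3 (0.17 log units; that floor lies within the scatter) and both are floors only, so the full size of the change remains unknown and no step beyond the scatter is established. Limits still dominate the series, so the reading rests on a single number: the limit of > 10000 nM in this assay, at which 2 of the 3 values shown sit.

The 5-chloro and 2-hydroxy parts of the entering group arrive together in compound 3, so the compounds shown cannot assign the result to either part alone. Also open, as far as these compounds go, is what a phenyl carrying only chlorine, only hydroxyl, an amine or a carboxylic acid would give at this place, and whether any such group would yield a step clearly beyond the scatter.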